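A Chain Methyl on a Slowly Cleared Hydroxamate

A few compounds are considered here, and "the series" means these few. Any claim that something is new, unique, unknown or untested is made for them only; others in the source may bear on it.

In an ADME assay on cells (Hepatocyte, Homo sapiens) for pharmacokinetics, read by LC-MS, with a stated time of 90 min, tested at 1 uM (a higher number here means faster removal of the compound, a lower number slower removal), compound 1 `Cc1ccc(Nc2c(NCCCCCC(=O)NO)c(=O)c2=O)cc1` gives 7.2 uL/min. Compound 2 `CN(C)c1ccc(Nc2c(NCCCCCC(=O)NO)c(=O)c2=O)cc1` gives only a limit, < 5 uL/min, in this assay. Among the compounds with values here, the single measured step, an at least 1.4-fold lower number from compound 1 to compound 2 (0.15 log units; that floor lies within the scatter), concerns the aromatic substituent and runs into (the limit of < 5 uL/min in this assay, at which 1 of the 2 values shown sits). Compound 3 `C[C@H](CCCCC(=O)NO)Nc1c(Nc2ccc(N(C)C)cc2)c(=O)c1=O` differs from compound 2 by methyl in place of hydrogen on a saturated chain carbon bound to a nitrogen on an aromatic ring and a saturated chain carbon. Within the data shown here, no measured step touches that chain position, so for compound 3 no shift beyond the scatter is expected, a number no lower from compound 2 to compound 3 (the limit leaves the size open). Compound 3 is therefore estimated at 5 uL/min in this assay, within a range from 2.5 uL/min to 10 uL/min, and a limit is again quite possible.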

Compound 3, intrinsic clearance in a liver preparation (reported as CLH), per the amount of preparation that the assay uses: < 5 uL/min
Compound 3: only a limit was reported; the forecaster's own chance of this, stated with the estimate: 50%; the middle value sits exactly at the limit.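

Within the data shown here, compound 2 and compound 3 are both reported only as limits in this assay, so no step between them can be read. Going by these compounds, whether the methyl on the chain changes the clearance, and by how much, stays open.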